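Cinnamate glycolamide esters: anilide para-substituent swap

The source may report more compounds than this note shows. Statements on the series, on what has been measured and on what is new or still open speak of the compounds shown alone.

Measured so far:
Compound 1, `COCOc1cc(/C=C/C(=O)OCC(=O)Nc2ccc(OC)cc2)ccc1OCc1ccccc1`: 133000 nM
Compound 2, `COCOc1cc(/C=C/C(=O)OCC(=O)Nc2ccc(Cl)cc2)ccc1OCc1ccccc1`: > 200000 nM
Compound 3, `COc1ccc(NC(=O)COC(=O)/C=C/c2cc(OC)c(OCc3ccc(Cl)c(Cl)c3)c(OC)c2)cc1`: 97800 nM

In a functional assay on BEL-7404 cells (Homo sapiens) for cytotoxicity, read by MTT assay, with a stated time of 72 h (a lower number here means a stronger inhibitor, a higher number a weaker inhibitor), compound 1 gives 133000 nM. For compound 2 the reading in this assay is a limit of the assay and not a number, > 200000 nM; this is the limit of > 200000 nM in this assay, at which 1 of the 3 values shown sits. The change between them is chloro in place of methoxy on an aromatic carbon and it made an at least 1.5-fold higher number from compound 1 to compound 2 (0.17 log units; that floor lies within the scatter). Compound 3, with a different core, gives 97800 nM in this assay; the difference between the core of compound 3 and the core of compound 1 is not broken down here, and the two values sit within the usual scatter of each other.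

Compound 4, `COc1cc(/C=C/C(=O)OCC(=O)Nc2ccc(Cl)cc2)cc(OC)c1OCc1ccc(Cl)c(Cl)c1`, is not yet measured. Going by the values given here, it differs from compound 3 by chloro in place of methoxy on an aromatic carbon, the same change as the one from compound 1 to compound 2, at the same kind of place. Carried over from that pair, the step from compound 3 to compound 4 in this assay is expected to be a 1.7-fold higher number from compound 3 to compound 4 (0.24 log units; within the scatter), a weakening of similar size, resting on an at least 1.5-fold higher number from compound 1 to compound 2 (0.17 log units; that floor lies within the scatter) and on the starting value of compound 3, 97800 nM. On that basis compound 4 is estimated at 170000 nM in this assay, with a range from 90000 nM to 320000 nM, and a real chance that only a limit is reported.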

Compound 4, half-maximal inhibitory concentration: > 200000 nM
Compound 4 ended at the assay's limit; the forecaster's own chance of this, stated with the estimate: 45%; at least 1.1-fold (0.07 log units) between middle value and limit.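

In this assay compound 4 reads > 200000 nM, a limit of the assay and not a number. Chloro in place of methoxy on the anilide ring gives an at least 2.0-fold higher number from compound 3 to compound 4 (0.31 log units; beyond the scatter), so the second core does not contradict the direction seen on the first, but the data give only a floor for the step on each core and no size that can be carried across: the same change on two cores in this assay, an at least 1.5-fold higher number (0.17 log units; that floor lies within the scatter) from compound 1 to compound 2 and an at least 2.0-fold higher number (0.31 log units; beyond the scatter) from compound 3 to compound 4; the limit leaves it open whether they differ Neither chloro compound has a measured number, so the series shows only that the readings of compound 2 and compound 4 lie past the range of the assay, and it gives no order between these two compounds and no true size for the change on either core: the limit of > 200000 nM in this assay, at which 2 of the 4 values shown sit.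

From the compounds shown here alone, it remains open whether an amine, a carboxylic acid or a hydroxyl group in place of the methoxy, or a longer chain in the link between the ester and the anilide, would bring the reading clearly lower on either core. Only a chloro analogue that gives a number inside the range of the assay could show whether the change has the same size on both cores.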